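Swapping methoxy for dimethylamino in compound 1

The compounds below may be only part of what the source reports. "The series", "measured", "known", "first", "only" and "open" are said of these compounds alone.

In a functional assay on HCT-116 cells (Homo sapiens) for inhibition, read by MTT assay, with a stated time of 48 h (on this read-out higher numbers stand for weaker inhibition and lower numbers for stronger inhibition), compound 1 (`COc1ccc(-n2c(S)nnc2-c2cc(OC)c(OC)c(OC)c2)cc1`) gives > 60000 nM, which is a limit of the assay and not a number. Compound 2 (`COc1ccc(-n2c(SCc3ccc(C)cc3)nnc2-c2cc(OC)c(OC)c(OC)c2)cc1`) gives 33300 nM. Among the measured compounds shown here, the only measured step is an at least 1.8-fold lower number from compound 1 to compound 2 (0.25 log units; that floor lies within the scatter), and it changes the group on the sulfur. Compound 3 (`COc1cc(-c2nnc(S)n2-c2ccc(N(C)C)cc2)cc(OC)c1OC`) differs from compound 1 elsewhere: dimethylamino in place of methoxy on an aromatic carbon, so 4-methoxyphenyl becomes 4-(dimethylamino)phenyl. The measured step therefore offers only weak guidance for this change, and no clear direction. The expected step is a number no higher from compound 1 to compound 3 (the limit leaves the size open), with nothing beyond the scatter anticipated. In this assay, compound 3 is estimated at 60000 nM, within an expected range from 20000 nM to 150000 nM.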

Compound 3, half-maximal inhibitory concentration: > 60000 nM
Compound 3: only a limit was reported; the forecaster's own chance of this, stated with the estimate: 55%; the middle value sits exactly at the limit.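

Compound 1 and compound 3 both give a limit of the assay and not a number, so no step between them can be read: the limit of > 60000 nM in this assay, at which 2 of the 3 values shown sit.

Going by these compounds, whether dimethylamino in place of methoxy on an aromatic carbon changes the result in this assay stays open.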